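The source may hold more compounds than are shown below. What is called first, only, known or untested is meant among the compounds shown, and "the series" means these compounds.

Measured in a functional assay on cells (Mast cell, Rattus norvegicus) for inhibition, with a stated time of 15 min; on this read-out higher numbers stand for an effect only at larger amounts of compound and lower numbers for an effect already at smaller amounts:
Compound 1 `Cn1nnnc1NC(=O)c1cc(=O)c2ccccc2o1` – > 18 ug/mL
Compound 2 `N#CC(C#N)=Cc1coc2ccccc2c1=O` – "nd(insoluble)" (no result reported)

Compound 1 gives > 18 ug/mL, which is a limit of the assay and not a number. Compound 2 is recorded as "nd(insoluble)" (no result reported), so it offers no comparison. For the measured compounds named here, no step between measured compounds is available to size a change.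

Compound 3 `O=C(Nc1nccs1)c1cc(=O)c2ccccc2o1` keeps the shared core and the amide of compound 1 and changes one group: 1,3-thiazol-2-yl in place of 1-methyl-1H-tetrazol-5-yl on an amide-type nitrogen.

The only anchor for an expectation is compound 1 with the limit of > 18 ug/mL in this assay, at which 1 of the 2 values shown sits. In this assay no change beyond the scatter is expected, in either direction. The expected step is a step that the limit leaves unreadable from compound 1 to compound 3. For compound 3 the estimate is 25 ug/mL, with an expected range of 10 ug/mL to 60 ug/mL.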

Compound 3, concentration for half-maximal effect: > 18 ug/mL
Compound 3 ended at the assay's limit (the forecaster's own chance of this, stated with the estimate: 55%); the middle value does not contradict the limit.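

Compound 1 and compound 3 both end at a limit of the assay and not at a number, so the change from 1-methyl-1H-tetrazol-5-yl to 1,3-thiazol-2-yl gives no readable step. The compounds shown leave open whether any group on this amide-type nitrogen gives a numerical value in this assay.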